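The source may hold more compounds than are shown below. What is called first, only, known or untested is meant among the compounds shown, and "the series" means these compounds.

Working notes on the series in an ADME assay on HCT-116 cells (Homo sapiens) for cytotoxicity, read by CellTiter-Glo, with a stated time of 72 h; a lower number here means a stronger inhibitor, a higher number a weaker inhibitor. Compound 1 `CC1CCN(C2CCN(S(=O)(=O)c3cccc(C(F)(F)F)c3)CC2)CC1` gives > 5000 nM, which is a limit and not a number. Compound 2 `Cc1cccc(S(=O)(=O)N2CCC(N3CCC(C)CC3)CC2)c1` gives > 5000 nM, again only a limit. Compound 3 `CC1CCN(C2CCN(S(=O)(=O)c3cccnc3F)CC2)CC1` gives > 10000 nM, also a limit. Among the compounds with values here, no compound therefore has a numeric value, and compound 2 has no rank among the others. The open question is compound 4 `Cc1ccc(C#N)c(S(=O)(=O)N2CCC(N3CCC(C)CC3)CC2)c1`, which differs from compound 2 by cyano in place of hydrogen on an aromatic carbon, ortho to a large group and para to a methyl group. Within the data shown here, two measured steps bear on this change, both on the same aromatic substituent position of the sulfonyl group's partner: a step that the two limits leave unreadable from compound 1 to compound 2, with methyl in place of trifluoromethyl on an aromatic carbon, and a step that the two limits leave unreadable from compound 2 to compound 3, with 2-fluoropyridin-3-yl in place of 3-methylphenyl on a sulfonyl sulfur. Neither has a readable size. With compound 2 at > 5000 nM, a limit, compound 4 is expected to give a limit as well, and no step beyond the scatter is expected in this assay. The expected change is a step that the limit leaves unreadable from compound 2 to compound 4. For compound 4 the estimated value is 7000 nM, with an expected range of 3500 nM to 15000 nM.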

Compound 4, half-maximal inhibitory concentration: > 5000 nM
Compound 4 ended at the assay's limit; the forecaster's own chance of this, stated with the estimate: 85%; the middle value does not contradict the limit.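

In this assay compound 4 gives > 5000 nM, which is a limit and not a number. Compound 2 also stands only at a limit, so no step can be read between compound 2 and compound 4. The compounds shown leave open what cyano in place of hydrogen on an aromatic carbon does to the value, as none of them has a numeric value.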